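The source may hold more compounds than are shown below. What is called first, only, known or untested is meant among the compounds shown, and "the series" means these compounds.

Going by the values given here, compound 3 `COc1cc(Cl)cc(-c2nn(-c3cccc(NC(=O)Nc4ccc(Cl)c(Cl)c4)c3)cc2-c2ccncc2)c1` gives 78% in a functional assay on OVCAR-8 cells (Homo sapiens) for inhibition, read by sulforhodamine B assay, with a stated time of 48 h, tested at 1 uM (a higher number here means a weaker effect of the compound at the concentration tested, a lower number a stronger effect), the highest of the three numbers measured so far. Compound 1 `COc1cc(Cl)cc(-c2nn(-c3cccc(NC(=O)Nc4ccc(Cl)c(C(F)(F)F)c4)c3)cc2-c2ccncc2)c1` gives 43%, and compound 2 `COc1cc(Cl)cc(-c2nn(-c3cccc(NC(=O)Nc4cc(C(F)(F)F)cc(C(F)(F)F)c4)c3)cc2-c2ccncc2)c1` gives 12%. Compound 4 `COc1cc(Cl)cc(-c2nn(-c3cccc(NC(=O)Nc4cccc(C(F)(F)F)c4)c3)cc2-c2ccncc2)c1` is not yet measured; it differs from compound 3 by 3-(trifluoromethyl)phenyl in place of 3,4-dichlorophenyl on an amide-type nitrogen. Among the compounds with values here, one measured step bears on this change: a number 35 percentage points higher from compound 1 to compound 3 (beyond the scatter). Compound 4 runs that step roughly the other way, since its 3-(trifluoromethyl)phenyl keeps a trifluoromethyl group and carries no chloro, so a fall in this assay beyond the scatter is expected, back toward the number of compound 1. The step expected is a number 28 percentage points lower from compound 3 to compound 4 (beyond the scatter). For compound 4 the estimate is 50%, with a range from 25% to 80%.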

Compound 4, a percentage reported as activity, at one concentration (the size of the read-out at that concentration, not a potency): 54%
For compound 4 the middle estimate is 4 percentage points below the measured one; the range from low to high includes it.
By their numbers in this assay, from the lowest: compound 2; then compound 1; then compound 4; then compound 3.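

In this assay, compound 4 shows that both extra substituents matter on this aryl group: hydrogen in place of trifluoromethyl gives a number 42 percentage points higher from compound 2 to compound 4 (beyond the scatter), and hydrogen in place of chloro gives a number 11 percentage points higher from compound 1 to compound 4 (beyond the scatter). The change from 3,4-dichlorophenyl to 3-(trifluoromethyl)phenyl on the amide-type nitrogen gives a number 24 percentage points lower from compound 3 to compound 4 (beyond the scatter), so a lone trifluoromethyl still gives a stronger effect than the two chloro groups. Nothing here explains these steps. As far as these compounds go, it remains open how a methoxy, a nitrile or a cyclohexyl group in place of this aryl group would read.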